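Amide-linked bisanilides at the assay limit: compound 3 to compound 4

This account rests on a few compounds, and the source may have more. Where it says the series, first, only, none or still open, it means among the compounds named here.

The measured compounds and their values:
compound 1 `COc1ccccc1C(=O)Nc1cccc(NC(=O)C2CCC2)c1`, > 30000 nM
compound 2 `O=C(Nc1cccc(NC(=O)c2cccc(Cl)c2)c1)c1cccc(F)c1`, > 30000 nM
compound 3 `O=C(Nc1cccc(NC(=O)c2cccc(Cl)c2)c1)c1ccc(F)cc1`, > 30000 nM

In an in vitro functional assay on HEK293-A cells for antagonist activity at metabotropic glutamate receptor 5 (Rattus norvegicus), read by calcium flux (on this read-out lower numbers stand for stronger inhibition and higher numbers for weaker inhibition), compound 3 gives > 30000 nM, which is a limit of the assay and not a number. Compound 2 likewise gives > 30000 nM in this assay, a limit. Compound 1 gives > 30000 nM in this assay, also a limit. Among the compounds with values here, the one step that can be followed, from compound 2 to compound 3, is a step that the two limits leave unreadable from compound 2 to compound 3. Within the data shown here, all three values shown sit at the same limit (the limit of > 30000 nM in this assay, at which 3 of the 3 values shown sit), so no step between them can be read.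

Compound 4 `O=C(Nc1cccc(NC(=O)C2CCC2)c1)c1cccc(Cl)c1` differs from compound 3 by cyclobutyl in place of 4-fluorophenyl on a carbonyl carbon. Among the measured compounds shown here, compound 1 already carries a cyclobutyl on a carbonyl carbon and sits at the limit, and no measured step bears on this change with a readable size. Compound 4 is therefore expected to sit near the same limit, a step of a number no higher from compound 3 to compound 4 (the limit leaves the size open), and its estimated value in this assay is 30000 nM with a range from 10000 nM to 100000 nM.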

Compound 4, half-maximal inhibitory concentration: 5270 nM
Compound 4: middle estimate off by 5.7-fold (0.76 log units), on the high side, outside the stated range (below it).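

In this assay, within the data shown here, compound 4 gives the first readable number, and it shows that the group on this carbonyl carbon matters: cyclobutyl in place of 4-fluorophenyl is an at least 5.6-fold lower number from compound 3 to compound 4 (0.75 log units; beyond the scatter), and cyclobutyl in place of 3-fluorophenyl is an at least 5.6-fold lower number from compound 2 to compound 4 (0.75 log units; beyond the scatter). Cyclobutyl is also present in compound 1, so it is not enough alone, and the other acyl group counts too: 3-chlorophenyl in place of 2-methoxyphenyl on a carbonyl carbon is an at least 5.6-fold lower number from compound 1 to compound 4 (0.75 log units; beyond the scatter). Each of these steps starts from a limit and not from a number, so each gives only a smallest size: the limit of > 30000 nM in this assay, at which 3 of the 4 values shown sit.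

From the compounds shown here alone, whether cyclopropyl, cyclohexyl or an open chain such as tert-butyl would do as well as cyclobutyl on this carbonyl carbon remains open. So does whether an amine on the 3-chlorophenyl ring would keep the number of compound 4.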